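Amide Nitrogen Methylation with a Difluorobenzyl Swap

The source may hold more compounds than are shown below. What is called first, only, known or untested is meant among the compounds shown, and "the series" means these compounds.

Measured compounds:
compound 1 `CC(C)c1c(C(=O)NCc2cccc(F)c2F)nn(-c2ccc(F)cc2)c1OC[C@@H](O)C[C@@H](O)CC(=O)O` 2 nM
compound 2 `Cc1cccc(CNC(=O)c2nn(-c3ccc(F)cc3)c(OC[C@@H](O)C[C@@H](O)CC(=O)O)c2C(C)C)c1` 4.9 nM
compound 3 `CC(C)c1c(C(=O)NCc2cccc(Cl)c2)nn(-c2ccc(F)cc2)c1OC[C@@H](O)C[C@@H](O)CC(=O)O` 5.4 nM

In an assay on microsomes from liver for inhibition of 3-hydroxy-3-methylglutaryl-coenzyme A reductase (Rattus norvegicus) (a higher number here means a weaker inhibitor, a lower number a stronger inhibitor), compound 3 gives the highest number of the three. Its nearest neighbour is compound 2, and the two values lie within the scatter of each other (a 1.1-fold higher number from compound 2 to compound 3 (0.04 log units; within the scatter)). The step from the strongest compound is larger (a 2.7-fold higher number from compound 1 to compound 3 (0.43 log units; beyond the scatter)).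

Compound 4 `CC(C)c1c(C(=O)N(C)Cc2ccc(F)c(F)c2)nn(-c2ccc(F)cc2)c1OC[C@@H](O)C[C@@H](O)CC(=O)O` has not yet been measured. It differs from compound 3 in one place: (3,4-difluorobenzyl)(methyl)amino in place of (3-chlorobenzyl)amino on a carbonyl carbon. Two things change at once here. The ring substituent moves from chloro to a pair of fluorines, and the amide nitrogen carries a methyl in place of its hydrogen. Of the measured steps, only the ring part has a precedent: a 2.7-fold higher number from compound 1 to compound 3 (0.43 log units; beyond the scatter) shows a different difluoro pattern giving a lower number than chloro, and a 1.1-fold higher number from compound 2 to compound 3 (0.04 log units; within the scatter) shows chloro and methyl on the ring as equivalent. For the measured compounds named here, no measured step covers a methyl on the amide nitrogen, so that part is unanchored. Compound 4 is therefore expected to give 8 nM in this assay, within 2 nM to 40 nM, a step of a 1.5-fold higher number from compound 3 to compound 4 (0.17 log units; within the scatter) that is estimated with wide uncertainty.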

Compound 4, half-maximal inhibitory concentration: 5.7 nM
The estimate for compound 4 lay 1.4-fold (0.15 log units) above the measured number, within the range that was stated.
By their numbers in this assay, from the lowest: compound 1; then compounds 2, 3 and 4 (each within the scatter of the next).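

In this assay, (3,4-difluorobenzyl)(methyl)amino on the carbonyl carbon stays within the scatter of both (3-chlorobenzyl)amino (a 1.1-fold higher number from compound 3 to compound 4 (0.02 log units; within the scatter)) and (3-methylbenzyl)amino (a 1.2-fold higher number from compound 2 to compound 4 (0.07 log units; within the scatter)), so this position accepts a group with 0 hydrogen-bond donors in place of one with 1 without a readable shift in the number. The (2,3-difluorobenzyl)amino group of compound 1 remains apart from this new group (a 2.9-fold higher number from compound 1 to compound 4 (0.45 log units; beyond the scatter)), as it does from the other two measured groups. No measurement here offers an explanation for these results.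

The methyl on the amide nitrogen and the two ring fluorines enter together, so their separate contributions cannot be read and could offset each other. From the compounds shown here alone, how the (3-chlorobenzyl)(methyl)amino group or an ethyl on the amide nitrogen would behave remains open.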